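A few compounds are considered here, and "the series" means these few. Any claim that something is new, unique, unknown or untested is made for them only; others in the source may bear on it.

Three compounds have been measured in an ADME assay on microsomes from liver (Homo sapiens) for metabolic stability; a lower number here means that the compound disappears faster, a higher number that the compound lasts longer:

compound 1, `CN1C(=O)COc2cc(Nc3ccc4ncn(CC5CC5)c4n3)cnc21`, 0.233 h;
compound 2, `Cc1cc(Nc2cnc3c(c2)OCC(=O)N3C)nc2c1ncn2CC1CC1`, 0.483 h;
compound 3, `CN1C(=O)COc2cc(Nc3cc4c(cc3F)ncn4CC3CC3)cnc21`, 0.533 h.

From compound 1 to compound 2 the change is methyl in place of hydrogen on an aromatic carbon, and in this assay it gave a 2.1-fold higher number from compound 1 to compound 2 (0.32 log units; beyond the scatter). Compound 3 has the highest of the three numbers, though its value and that of compound 2 lie within the scatter of each other. The difference between the cores of compound 1 and compound 3 is not broken down here.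

Compound 4, `Cc1c(F)c(Nc2cnc3c(c2)OCC(=O)N3C)cc2c1ncn2CC1CC1`, differs from compound 3 by methyl in place of hydrogen on an aromatic carbon. This is the same kind of change as that from compound 1 to compound 2, but the surroundings differ: there the methyl entered a six-membered aromatic ring with one nitrogen, opposite the ring nitrogen, whereas here it enters a six-membered aromatic ring of carbon only, ortho to a fluoro group. Because the earlier step gave a 2.1-fold higher number from compound 1 to compound 2 (0.32 log units; beyond the scatter), a step of similar size is expected from compound 3 to compound 4, namely a 1.9-fold higher number from compound 3 to compound 4 (0.27 log units; within the scatter). Compound 4 is therefore estimated at 1 h in this assay, expected to lie between 0.5 h and 2 h.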

Compound 4, half-life: 0.65 h
The estimate for compound 4 lay 1.5-fold (0.19 log units) above the measured number, and the stated range covers the measured number.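

In this assay the methyl in place of hydrogen on an aromatic carbon gave a 1.2-fold higher number from compound 3 to compound 4 (0.09 log units; within the scatter) on the second core. The two steps cannot be told apart: the same change on two cores in this assay, a 2.1-fold higher number (0.32 log units; beyond the scatter) from compound 1 to compound 2 and a 1.2-fold higher number (0.09 log units; within the scatter) from compound 3 to compound 4, 1.7-fold (0.23 log units) apart, within the scatter of two such steps. This shows that the data give no sign of the change behaving differently on these two cores, but it does not show that the effect carries over by a fixed amount, since only two pairs are shown and the second step alone cannot be separated from the scatter.

From the compounds shown here alone, it remains open whether an ethyl, a methoxy or an amine on the same aromatic carbon would act as methyl does. The compounds shown also leave open what a chloro group in place of the fluoro group would do to the step.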